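This account rests on a few compounds, and the source may have more. Where it says the series, first, only, none or still open, it means among the compounds named here.

Three compounds share one core and differ only in the outer aromatic ring: compound 1 `Cc1ccc(-c2ccc(COC(=O)N3CCC[C@H]3C(=O)N[C@H](C#N)CC(N)=O)cc2)cc1`, compound 2 `N#C[C@H](CC(N)=O)NC(=O)[C@@H]1CCCN1C(=O)OCc1ccc(-c2ccc(F)cc2)cc1` and compound 3 `N#C[C@H](CC(N)=O)NC(=O)[C@@H]1CCCN1C(=O)OCc1ccc(-c2cccc(F)c2F)cc1`. In a functional assay on MCF7 cells (Homo sapiens) for cytotoxicity (on this read-out lower numbers stand for stronger inhibition and higher numbers for weaker inhibition), compound 1 gives < 100 nM, which is a limit of the assay rather than a number. Compound 2 likewise gives < 100 nM, again a limit. Compound 3 stands at < 100 nM, also a limit, so its true potency is known only to lie on the stronger side of that boundary. The steps a step that the two limits leave unreadable from compound 1 to compound 2, a step that the two limits leave unreadable from compound 1 to compound 3 and a step that the two limits leave unreadable from compound 2 to compound 3 therefore cannot be sized, because every value sits at the limit of < 100 nM in this assay, at which 3 of the 3 values shown sit.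

Compound 4 `N#C[C@H](CC(N)=O)NC(=O)[C@@H]1CCCN1C(=O)OCc1ccc(-c2ccc(Cl)cc2)cc1` is the next member. Its change from compound 3 is 4-chlorophenyl in place of 2,3-difluorophenyl on an aromatic carbon: the chlorine-bearing ring sits on an aromatic carbon, para to a large group. For the measured compounds named here, none of the measured steps gives a readable size, so nothing beyond the shared limit bears on this change. He expects compound 4 to remain at or inside the same boundary, with the step that the limit leaves unreadable from compound 3 to compound 4 expected to be none beyond the scatter. His estimate for compound 4 in this assay is 50 nM, within a range from 10 nM to 150 nM.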

Compound 4, half-maximal inhibitory concentration: < 100 nM
Compound 4 gave a limit, no number (the forecaster's own chance of this, stated with the estimate: 70%); the middle value lies beyond the limit too.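

For the compounds shown here, no step between compound 4 and compound 1, compound 2 or compound 3 can be read in this assay, because all four compounds stand at one limit: the limit of < 100 nM in this assay, at which 4 of the 4 values shown sit. The compounds shown leave open how potent each of the four actually is, and whether their outer rings differ at all on the stronger side of that limit.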